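This account rests on a few compounds, and the source may have more. Where it says the series, first, only, none or still open, it means among the compounds named here.

Among the measured compounds shown here, in a functional assay on HCT-116 cells (Homo sapiens) for inhibition (a higher number here means a weaker inhibitor, a lower number a stronger inhibitor), compound 1 (`CCNC(=O)c1noc(-c2cc(C(C)C)c(O)cc2O)c1-c1cc(COCC(=O)O)no1`) has the entry "not determined" (no result reported), so only two numbers are available. Compound 2 (`C=CNCc1cc(-c2c(C(=O)NCC)noc2-c2cc(C(C)C)c(O)cc2O)on1`) gives 121 nM and compound 3 (`CCNC(=O)c1noc(-c2cc(C(C)C)c(O)cc2O)c1-c1cc(CN(CC)CC)no1`) gives 38 nM, the lower of the two. Compound 4 (`CCNC(=O)c1noc(-c2cc(C(C)C)c(O)cc2O)c1-c1cc(C(N)=O)no1`) carries carbamoyl in place of (diethylamino)methyl on an aromatic carbon. For the measured compounds named here, the only measured step that bears on this change is a 3.2-fold lower number from compound 2 to compound 3 (0.50 log units; beyond the scatter), where diethylamino replaces vinylamino. Neither compound carries carbamoyl, so this step is only a loose guide, and a step of similar or somewhat larger size is expected, towards a higher number. The expected step is a 2.9-fold higher number from compound 3 to compound 4 (0.46 log units; beyond the scatter). Compound 4 is estimated at 110 nM, with an expected range of 35 nM to 350 nM.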

Compound 4, half-maximal inhibitory concentration: 79 nM
For compound 4 the middle estimate is 1.4-fold (0.14 log units) above the measured one; measured number inside the range.
By their numbers in this assay, from the lowest: compound 3; then compounds 4 and 2 (each within the scatter of the next).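

In this assay, carbamoyl in place of (diethylamino)methyl next to the ring nitrogen gives a 2.1-fold higher number from compound 3 to compound 4 (0.32 log units; beyond the scatter), so compound 4 keeps a nanomolar value without an amine at this position. Carbamoyl in place of (vinylamino)methyl gives a 1.5-fold lower number from compound 2 to compound 4 (0.19 log units; within the scatter), so these two groups cannot be told apart here. No measurement shown explains these steps. The compounds shown leave open how a carboxylic acid placed directly on this ring carbon would compare with carbamoyl. They also leave open whether a longer chain carrying a piperidine would match (diethylamino)methyl.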